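The source may report more compounds than this note shows. Statements on the series, on what has been measured and on what is new or still open speak of the compounds shown alone.

Measured so far in an ADME assay on BHK-21 cells (Mesocricetus auratus) for cytotoxicity, read by MTT assay, with a stated time of 96 h; on this read-out higher numbers stand for lower toxicity in this test and lower numbers for higher toxicity in this test:
compound 1 `O=[N+]([O-])c1cccc(/N=N/N2CCCC2)c1` gives 42000 nM.
compound 2 `O=[N+]([O-])c1ccc(/N=N/N2CCCC2)cc1` gives >= 100000 nM, which is a limit of the test rather than a number.
compound 3 `FC(F)(F)c1cccc(/N=N/c2ccc(NC[C@@H]3CCCN4CCCC[C@H]34)c3c2CCCC3)c1` gives 14000 nM.

Among the two plain numbers, compound 3 holds the lower one, which in this read-out stands for the higher toxicity of the pair; its nearer neighbour, compound 1, sits above it by a distance that goes beyond the usual scatter. The remaining result, that of compound 2, is a limit and cannot be ranked against either number.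

Compound 4 `Fc1ccc(F)c(/N=N/c2ccc(NC[C@@H]3CCCN4CCCC[C@H]34)c3c2CCCC3)c1` has not yet been tested. It differs from compound 3 in one place: 2,5-difluorophenyl in place of 3-(trifluoromethyl)phenyl on a double-bonded nitrogen. Both groups are a six-membered aromatic ring of carbon only bearing fluorine, with no hydrogen-bond donors or acceptors and no charge, so the change is a modest one. Among the compounds with values here, no pair of measured compounds shows a change of this kind, so there is no measured step to lean on; the expectation for this assay is a step that stays within the scatter, with no clear direction. Compound 4 is therefore estimated at 16000 nM, in a range from 6000 nM to 45000 nM, which amounts to an expected step of a 1.1-fold higher number from compound 3 to compound 4 (0.06 log units; within the scatter).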

Compound 4, half-maximal cytotoxic concentration: 38000 nM
Beside the measured number, compound 4's estimate is 2.4-fold (0.38 log units) below it; the range from low to high includes it.
By their numbers in this assay, from the lowest: compound 3; then compounds 4 and 1 (each within the scatter of the next). At a limit, above all of these: compound 2.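

In this assay, the group on a double-bonded nitrogen proves able to shift the result: 2,5-difluorophenyl in place of 3-(trifluoromethyl)phenyl gives a 2.7-fold higher number from compound 3 to compound 4 (0.43 log units; beyond the scatter), which on this read-out means lower toxicity in this test. Within the data shown here, this is the first step that isolates a change in one place, and it shows that even a swap between two similar fluorine-bearing aromatic rings can move the number past the usual scatter. Nothing at hand bears on why this step occurs.

Going by these compounds, it remains open whether the shift comes from losing the trifluoromethyl group or from gaining the two fluorines. On these data alone, it is also open how a plain phenyl ring, or a phenyl ring carrying an amine or a carboxylic acid, would behave in this place.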